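Replacing 4-chlorophenyl with 1H-pyrrol-2-yl: compound 3 to compound 4

A few compounds are considered here, and "the series" means these few. Any claim that something is new, unique, unknown or untested is made for them only; others in the source may bear on it.

Compound 1 `CCc1nc2ccc(Cl)cn2c1C(=O)NCc1ccc(-c2ccc(C#N)cc2)cc1` - > 2 h (a limit)
Compound 2 `CCc1nc2cc(Cl)ccn2c1C(=O)NCc1ccc(-c2ccc(C)cc2)cc1` - 0.423 h
Compound 3 `CCc1nc2cc(Cl)ccn2c1C(=O)NCc1ccc(-c2ccc(Cl)cc2)cc1` - > 2 h (a limit)

In an ADME assay (liver) for metabolic stability, with Liver microsome (Homo sapiens) as the target, using microsomes (a lower number here means that the compound disappears faster, a higher number that the compound lasts longer), compound 3 gives > 2 h as a limit and not a number. Compound 1 gives > 2 h as a limit too. Compound 3 therefore has no exact place: it stands on the limit of > 2 h in this assay, at which 2 of the 3 values shown sit, and not on a measured number.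

Compound 4 `CCc1nc2cc(Cl)ccn2c1C(=O)NCc1ccc(-c2ccc[nH]2)cc1` carries 1H-pyrrol-2-yl in place of 4-chlorophenyl on an aromatic carbon and is still to be measured.

Among the compounds with values here, the one measured step that bears on this change is an at least 4.7-fold higher number from compound 2 to compound 3 (0.67 log units; beyond the scatter) and it falls on the same 4-chlorophenyl group that leaves here. Compound 2 at 0.423 h lacks that chloro group, as compound 4 also does, so a lower number in this assay is expected for compound 4. A single step is thin ground, and the whole ring changes here, so the range is kept wide and a reading at the limit stays possible. The expected change is an at least 2.8-fold lower number from compound 3 to compound 4 (0.45 log units; beyond the scatter) and it lies beyond the scatter. For compound 4 the estimate is 0.7 h with an expected range from 0.25 h to 2 h in this series.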

Compound 4, half-life: > 2 h
Compound 4 ended at the assay's limit (the forecaster's own chance of this, stated with the estimate: 20%); middle value at least 2.8-fold (0.45 log units) away from the limit.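

In this assay the change from 4-methylphenyl to 1H-pyrrol-2-yl gives an at least 4.7-fold higher number from compound 2 to compound 4 (0.67 log units; beyond the scatter) and so shows that the chloro group of 4-chlorophenyl is not required for a long half-life at this place, para to a large group. Within the data shown here, a five-membered aromatic ring with a hydrogen-bond donor serves here as well as the six-membered ring of carbon only, and compound 2, with 4-methylphenyl, now stands alone among the compounds differing at this place as the one with a measured number, 0.423 h, rather than a limit. Compound 3 and compound 4 both end as limits, so the step between them cannot be read and no order can be given for them, and the assay has little room left to separate further changes in this series: the limit of > 2 h in this assay, at which 3 of the 4 values shown sit.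

Whether the hydrogen on the pyrrole nitrogen matters stays open, as a 1-methylpyrrol-2-yl group is not among the compounds shown. So does the outcome at this place for an unsubstituted phenyl, a saturated ring such as piperidine, or a phenyl carrying a carboxylic acid or an amine.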